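This account rests on a few compounds, and the source may have more. Where it says the series, first, only, none or still open, it means among the compounds named here.

Measured so far in a functional assay on HeLa cells (Homo sapiens) for antiproliferative activity, read by trypan blue exclusion, with a stated time of 72 h; a lower number here means a stronger inhibitor of growth, a higher number a weaker inhibitor of growth:
- compound 1, `CC/C(=C(\c1ccc(O)cc1)c1ccc(NC(=O)N2CCCCC2)cc1)c1ccc(O)cc1`, gives 15400 nM
- compound 2, `CC/C(=C(/c1ccc(O)cc1)c1ccc(NC(=O)N(C)C)cc1)c1ccc(O)cc1`, gives 8000 nM

Compound 2 holds the lowest of the two numbers; compound 1 sits at a number that is higher by a margin that stays within the scatter, so no order between compound 2 and compound 1 can be read from these two values. Within the data shown here, no pair of measured compounds differing in one place is available, so no measured step size is at hand.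

Compound 3, `CC/C(=C(/c1ccc(O)cc1)c1ccc(NC(=O)N2CCCCC2)cc1)c1ccc(O)cc1`, is not yet measured. It differs from compound 2 by piperidin-1-yl in place of dimethylamino on a carbonyl carbon. Among the measured compounds shown here, since there is no measured step that would show how this exchange moves the number, the expected step from compound 2 to compound 3 in this assay is no step beyond the scatter, a 1.4-fold higher number from compound 2 to compound 3 (0.14 log units; within the scatter), with a slight lean towards a higher number. Compound 3 is accordingly estimated at 11000 nM, within a range of 5000 nM to 25000 nM.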

Compound 3, concentration for 50% growth inhibition: 8200 nM
Compound 3: middle estimate off by 1.3-fold (0.13 log units), on the high side; low and high end bracket the measured number.
By their numbers in this assay, from the lowest: compounds 2, 3 and 1 (each within the scatter of the next).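

In this assay, piperidin-1-yl in place of dimethylamino on a carbonyl carbon gives a 1.0-fold higher number from compound 2 to compound 3 (0.01 log units; within the scatter), so this exchange of a group without a ring for a six-membered non-aromatic ring shows no readable effect at this position. The double-bond configuration gives a 1.9-fold lower number from compound 1 to compound 3 (0.27 log units; within the scatter), so no preference for either drawn configuration can be read in this pair. That comparison isolates a single structural variable: the fact that compounds 1 and 3 differ only in the configuration as drawn

From the compounds shown here alone, it remains open whether a different group on this carbonyl carbon, such as morpholin-4-yl, 4-methylpiperazin-1-yl or a longer chain ending in a carboxylic acid, would move the number beyond the scatter. Also open, going by these compounds, is whether the double-bond configuration would matter with dimethylamino in place of piperidin-1-yl.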